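This account rests on a few compounds, and the source may have more. Where it says the series, first, only, none or still open, it means among the compounds named here.

Measured compounds in an ADME assay on Huh-7 cells (Homo sapiens) for cytotoxicity; a lower number here means that less compound is tolerated, a higher number that more compound is tolerated:
- compound 1 `Cc1ccc(C(=O)NC(=S)N2CCc3c(OCCCCCOc4ccc(Cl)cc4)cccc32)cc1`: > 50000 nM, a limit of the assay rather than a number
- compound 2 `CN(C)c1ccc(C(=O)NC(=S)N2CCc3c(OCCCCCOc4ccc(Cl)cc4)cccc32)cc1`: > 50000 nM, likewise a limit of the assay

Compound 2 stands at the limit of this assay; its value is a limit and not a number, so its true tolerance is known only to lie beyond that point. Among the measured compounds shown here, the one step among the measured compounds, a step that the two limits leave unreadable from compound 1 to compound 2, cannot be read, both ends sitting at the limit as the limit of > 50000 nM in this assay, at which 2 of the 2 values shown sit, records.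

Compound 3 `O=C(NC(=S)N1CCc2c(OCCCCCOc3ccc(Cl)cc3)cccc21)c1ccsc1` differs from compound 2 by thiophen-3-yl in place of 4-(dimethylamino)phenyl on a carbonyl carbon. For the measured compounds named here, no measured step touches a change of this kind, and the single step, a dimethylamino group replacing a methyl group, yields no size at all. Going by the values given here, what the data show is only that both measured compounds are tolerated up to the limit, and the expectation for compound 3 rests on that alone. Compound 3 is expected to sit at or near the same limit, 50000 nM, within 20000 nM to 200000 nM. The step of a number no higher from compound 2 to compound 3 (the limit leaves the size open) is therefore expected to be none beyond the scatter, the main uncertainty being whether a number rather than a limit is reported at all.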

Compound 3, half-maximal cytotoxic concentration: > 50000 nM
Compound 3: no number, only a limit (the forecaster's own chance of this, stated with the estimate: 80%); the middle value lies on the limit itself.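

Compound 3 also gives only a limit in this assay, not a number, so the steps linking compound 1, compound 2 and compound 3 cannot be read: the limit of > 50000 nM in this assay, at which 3 of the 3 values shown sit.

The compounds shown leave open how far the true tolerated concentration of each lies past that limit, and whether 4-methylphenyl, 4-(dimethylamino)phenyl and thiophen-3-yl differ at all.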